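The source may hold more compounds than are shown below. What is called first, only, known or untested is meant among the compounds shown, and "the series" means these compounds.

The measured compounds:
Compound 1 `O=C1C=CC(=O)C(c2cc(-c3ccc(C(=O)N4CCCCC4)s3)on2)=C1`: in a functional assay on PC-3 cells (Homo sapiens) for cytotoxicity, read by XTT assay, with a stated time of 72 h (a higher number here means a weaker inhibitor, a lower number a stronger inhibitor), compound 1 reaches only a limit, > 30000 nM.
Compound 2 `COc1ccc(OC)c(-c2cc(-c3ccc(C(=O)N(C)Cc4ccccc4)s3)on2)c1`: in this assay compound 2 also reaches only a limit, > 30000 nM.
Compound 3 `CCCN(C)C(=O)c1ccc(-c2cc(C3=CC(=O)C=CC3=O)no2)s1`: in this assay compound 3 reaches a limit too, < 30000 nM.

Compound 3 therefore stands on the inhibiting side of the cut-off, while the two other compounds sit on the far side; none of the three is a number. Among the measured compounds shown here, the one single-place step, a number no higher from compound 1 to compound 3 (the limit leaves the size open), is a change of methyl(propyl)amino in place of piperidin-1-yl on a carbonyl carbon, and its size cannot be read, since both ends are limits: the limit of < 30000 nM in this assay, at which 1 of the 3 values shown sits, and (the limit of > 30000 nM in this assay, at which 2 of the 3 values shown sit).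

Compound 4 `CN(Cc1ccccc1)C(=O)c1ccc(-c2cc(C3=CC(=O)C=CC3=O)no2)s1` is the next step from compound 3, and the change is phenyl in place of ethyl on a saturated chain carbon bound to an amide-type nitrogen. Compound 2 carries the same benzyl(methyl)amino group on a different core and reaches only the far limit, but that is not a single-place comparison. With no readable step to lean on, compound 4 is expected to stay near compound 3, and the step that the limit leaves unreadable from compound 3 to compound 4 is an estimate with wide uncertainty. Compound 4 is thus expected to give about 12000 nM, within a range from 2000 nM to 60000 nM.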

Compound 4, half-maximal inhibitory concentration: 11000 nM
Estimate against measurement, compound 4: 1.1-fold (0.04 log units) above; measured number inside the range.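

In this assay, among the compounds shown here, compound 4 gives 11000 nM, the only value shown that is a number and not a limit, so an amide carrying phenyl on this saturated chain carbon can be placed on the scale. With benzyl(methyl)amino in place of piperidin-1-yl on a carbonyl carbon, the data give an at least 2.7-fold lower number from compound 1 to compound 4 (0.43 log units; beyond the scatter). With that amide kept, and a group of 8 heavy atoms holding a non-aromatic six-membered ring of carbon in place of a group of 10 heavy atoms holding an aromatic one, on an aromatic carbon, the data give an at least 2.7-fold lower number from compound 2 to compound 4 (0.43 log units; beyond the scatter), so benzyl(methyl)amino alone does not account for the number seen with compound 4.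

On these data alone, the step that links compound 3 and compound 4 cannot be read, so how far phenyl moves the value away from that of ethyl remains unknown. Also open, as far as these compounds go, is what a cyclohexyl group or a carboxylic acid in place of phenyl on this saturated chain carbon would give.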